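Two Fluorines in Place of a Methoxy Group

A few compounds are considered here, and "the series" means these few. Any claim that something is new, unique, unknown or untested is made for them only; others in the source may bear on it.

Compound 3 `COc1ccc(C(=O)/C=C/c2cc(-c3cc(OC)c(OC)c(OC)c3)n[nH]2)cc1` was tested in a functional assay on SF-539 cells (Homo sapiens) for inhibition, read by sulforhodamine B assay, with a stated time of 48 h (on this read-out higher numbers stand for weaker inhibition of growth and lower numbers for stronger inhibition of growth), where compound 3 gives 3080 nM. That is the highest of the three numbers measured here. Its nearest neighbour is compound 1 `COc1cc(-c2cc(/C=C/C(=O)c3ccc(N)cc3)[nH]n2)cc(OC)c1OC`, which in this assay gives 2660 nM, and the two lie within the scatter of each other. Furthest away is compound 2 `COc1ccc(-c2cc(/C=C/C(=O)c3cc(OC)c(OC)c(OC)c3)[nH]n2)cc1OC`, which in this assay gives 1480 nM, a gap beyond the scatter. Within the data shown here, the only one-place step among the measured compounds is a 1.2-fold higher number from compound 1 to compound 3 (0.06 log units; within the scatter), a change that left the number essentially unmoved.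

Compound 4 `COc1cc(-c2cc(/C=C/C(=O)c3ccc(F)c(F)c3)[nH]n2)cc(OC)c1OC` differs from compound 3 at one place: 3,4-difluorophenyl in place of 4-methoxyphenyl on a carbonyl carbon. Among the measured compounds shown here, no measured step exchanges a methoxy group for fluorine, so the expectation rests on the one step available. Because the step of a 1.2-fold higher number from compound 1 to compound 3 (0.06 log units; within the scatter) stayed within the scatter, a further exchange of this kind is expected to move the number little. The expected step is therefore a 1.1-fold lower number from compound 3 to compound 4 (0.04 log units; within the scatter) in this assay. The estimate for compound 4 in this assay is 2800 nM, with a range from 900 nM to 9000 nM.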

Compound 4, concentration for total growth inhibition: 17700 nM
Beside the measured number, compound 4's estimate is 6.3-fold (0.80 log units) below it; the whole stated range lies below it.
By their numbers in this assay, from the lowest: compounds 2, 1 and 3 (each within the scatter of the next, the first and the last beyond it); then compound 4.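

Among these compounds, the group on the carbonyl carbon matters more than the earlier compounds suggested: in this assay, 3,4-difluorophenyl in place of 4-methoxyphenyl gives a 5.7-fold higher number from compound 3 to compound 4 (0.76 log units; beyond the scatter) and so means weaker inhibition of growth. Set against 4-aminophenyl, the same group gives a 6.7-fold higher number from compound 1 to compound 4 (0.82 log units; beyond the scatter) and points the same way, so this position tolerates the swap between the two groups of compounds 1 and 3 but not the change to 3,4-difluorophenyl. No measurement at hand explains this difference.

Going by these compounds, what stays open is which feature of the new group carries the change, since it differs from the other two in more than one respect. A phenyl ring with a single fluorine, or with a hydroxyl group, on this carbonyl carbon could show whether such compounds fall nearer compound 3 or compound 4.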